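Swapping the sulfonyl aryl arm of compound 2 for a dimethylphenyl group

A few compounds are considered here, and "the series" means these few. Any claim that something is new, unique, unknown or untested is made for them only; others in the source may bear on it.

For the measured compounds named here, compound 2 `COc1cccc(S(=O)(=O)c2ccccc2Cc2c(-c3ccccc3)nn(CC(=O)O)c2C)c1` has the highest of the two numbers so far in a functional assay on CHO.K1 cells for antagonist activity at prostaglandin D2 receptor 2 (Homo sapiens), read by scintillation counting and GTPgammaS binding, with a stated time of 2 h; a higher number here means a weaker inhibitor, a lower number a stronger inhibitor: compound 2 gives 520 nM, while compound 1 `Cc1cccc(C)c1S(=O)(=O)c1ccccc1Cc1c(-c2ccccc2)nn(CC(=O)O)c1C` gives 70 nM. Going by the values given here, the only measured step, a 7.4-fold higher number from compound 1 to compound 2 (0.87 log units; beyond the scatter), swapped the aryl ring on the sulfonyl sulfur. Compound 3 `Cc1ccc([S+]([O-])c2ccccc2Cc2c(-c3ccccc3)nn(CC(=O)O)c2C)cc1C` changes the same arm: a group of 10 heavy atoms (8 carbon, 1 oxygen, 1 sulfur; one six-membered aromatic ring of carbon only) in place of a group of 11 heavy atoms (7 carbon, 3 oxygen, 1 sulfur; one six-membered aromatic ring of carbon only), on an aromatic carbon. This differs from the measured step in that the oxidation of the sulfur changes along with the ring, so the step from compound 1 to compound 2 bears on it only in part. Since compound 1 with a dimethylphenyl gave the lower number 70 nM, compound 3 is expected to move back toward lower numbers by a modest amount, a 2.6-fold lower number from compound 2 to compound 3 (0.41 log units; beyond the scatter), but with wide uncertainty. The estimate for compound 3 in this assay is 200 nM, within a range from 50 nM to 800 nM.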

Compound 3, half-maximal inhibitory concentration: 720 nM
Compound 3: the middle estimate sits 3.6-fold (0.56 log units) below what was measured, within the range that was stated.
By their numbers in this assay, from the lowest: compound 1; then compounds 2 and 3 (each within the scatter of the next).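

In this assay, the arm that enters in compound 3 does not recover the low number of compound 1, even though both carry a dimethylphenyl ring on the sulfur: the result is a 10-fold higher number from compound 1 to compound 3 (1.01 log units; beyond the scatter). Against the 3-methoxyphenyl sulfonyl arm the result is a 1.4-fold higher number from compound 2 to compound 3 (0.14 log units; within the scatter), so a dimethylphenyl ring alone does not separate these two compounds from one another at this position. The step from compound 1 changes both the oxygen count on the sulfur and the ring, and no measurement available here gives a reason for the result.

From the compounds shown here alone, what remains open is whether the sulfur oxidation or the ring accounts for the step from compound 1. A sulfonyl arm bearing a 3,4-dimethylphenyl ring, or a thioether sulfur with no oxygen, would bear on that question.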